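Chloro in Place of Methyl: One Step to Compound 3

The compounds below may be only part of what the source reports. "The series", "measured", "known", "first", "only" and "open" are said of these compounds alone.

Compound 1 `Cc1ncc(C(F)(F)F)c(N2CC[C@@H](C)N(C(=O)c3ccccc3-n3nccn3)CC2)n1`: 4200 nM
Compound 2 `Cc1cnc(Cl)nc1N1CC[C@@H](C)N(C(=O)c2ccccc2-n2nccn2)CC1`: 760 nM

Of the compounds shown here, two have so far been measured in an assay on CHO cells for binding affinity to Orexin receptor type 2 (Homo sapiens), read by radioligand binding, with a stated time of 3 h; a lower number here means a stronger inhibitor, a higher number a weaker inhibitor. Compound 2 gives the lowest number of the two, with 760 nM; compound 1 gives a higher number, and that gap lies beyond the usual scatter. Compound 3 `C[C@@H]1CCN(c2nc(Cl)ncc2Cl)CCN1C(=O)c1ccccc1-n1nccn1` has not yet been measured. It differs from compound 2 in one place: chloro in place of methyl on an aromatic carbon. For the measured compounds named here, no measured pair shows this same exchange, so there is nothing to lean on for its size. One heavy atom is swapped for one heavy atom, which is usually a modest step; the expected change from compound 2 to compound 3 is a 1.1-fold lower number from compound 2 to compound 3 (0.04 log units; within the scatter), within the scatter in either direction. Compound 3 is expected to give about 700 nM, plausibly between 250 nM and 2000 nM.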

Compound 3, inhibition constant: 850 nM
Beside the measured number, compound 3's estimate is 1.2-fold (0.08 log units) below it; low and high end bracket the measured number.
By their numbers in this assay, from the lowest: compounds 2 and 3 (each within the scatter of the next); then compound 1.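

Chloro in place of methyl on this aromatic carbon, ortho to a large group, gives in this assay a 1.1-fold higher number from compound 2 to compound 3 (0.05 log units; within the scatter), so the two groups cannot be told apart at this position. For the compounds shown here, this is the first reading of this exchange, and it shows that the position accepts either group with no measurable difference. The compounds shown leave open how an amine, a methoxy group or a nitrile would read at this carbon. No measured evidence accounts for the match between methyl and chloro.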